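Amide nitrogen substituent and paw edema inhibition

The source may hold more compounds than are shown below. What is called first, only, known or untested is meant among the compounds shown, and "the series" means these compounds.

Compound 1 `COc1cc2c(cc1OC)C(CC(=O)N(C)C)CC2` carries a dimethylamino group on the carbonyl carbon, and in a functional assay on the whole organism (strain Wistar) for inhibition, with Rattus norvegicus as the target, read by paw edema, with stated times of 60 min and 24 h, at a dose of 100 mg/kg by the oral route (on this read-out lower numbers stand for less inhibition and higher numbers for more inhibition at the one dose given (going by the name of the read-out)), compound 1 gives 23.3%. Compound 2 `COc1cc2c(cc1OC)C(CC(=O)NC(C)(C)C)CC2` has (tert-butyl)amino in place of dimethylamino on a carbonyl carbon; in this assay compound 2 gives 40%, which is a number 16.7 percentage points higher from compound 1 to compound 2 (beyond the scatter). Going by the values given here, of the two numbers so far, compound 2 stands highest, with compound 1 the only other point. Compound 3 `CCCCCCNC(=O)CC1CCc2cc(OC)c(OC)cc21` differs from compound 2 by hexyl in place of tert-butyl on an amide-type nitrogen. Among the compounds with values here, the only measured step concerns the amide nitrogen, and it carried a modest gain when one alkyl pattern on that nitrogen was exchanged for another. The present change again exchanges one alkyl group on the amide nitrogen for another, so a step of similar or smaller size is expected, in either direction, most likely within the scatter; the expected step is no change at the digits printed from compound 2 to compound 3 (within the scatter). Compound 3 is therefore estimated at 40%, in a range from 20% to 60%.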

Compound 3, a percentage reported as inhibition, in the whole organism at one dose (the size of the read-out at that dose, not a potency): 45.5%
Estimate against measurement, compound 3: 5.5 percentage points below; measured number inside the range.
By their numbers in this assay, from the lowest: compound 1; then compounds 2 and 3 (each within the scatter of the next).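

In this assay, hexyl in place of tert-butyl on the amide-type nitrogen gives a number 5.5 percentage points higher from compound 2 to compound 3 (within the scatter), so these two alkyl groups cannot be told apart at this position, even though they differ in size and shape. Hexylamino in place of dimethylamino on the carbonyl carbon gives a number 22.2 percentage points higher from compound 1 to compound 3 (beyond the scatter), so a second group now stands clear of compound 1, and in these three compounds both amides with a single alkyl group on the nitrogen lie beyond the scatter from the dimethylamino amide. Nothing available gives a reason for either step.

Open, from the compounds shown here alone, is whether a longer chain such as decyl, a cyclohexyl or benzyl group on the nitrogen, or the plain primary amide would keep this level. Also open, going by these compounds, is how a carboxylic acid in place of the amide would read out.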